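A few compounds are considered here, and "the series" means these few. Any claim that something is new, unique, unknown or untested is made for them only; others in the source may bear on it.

Working notes on the series.

Of the compounds shown here, three have been measured and one is pending. Compound 1 `CCOC(=O)c1c(-c2cccc(F)c2)[nH]c2cc(OC)ccc2c1=O`, compound 2 `CCOC(=O)c1c(-c2cccc(Cl)c2)[nH]c2cc(OC)ccc2c1=O` and compound 3 `CCOC(=O)c1c(-c2cccc(-c3ccccc3)c2)[nH]c2cc(OC)c(Cl)cc2c1=O` were run in an ADME assay on HepG2 cells (Homo sapiens) for cytotoxicity, read by luminescence, with a stated time of 72 h; on this read-out lower numbers stand for an effect already at smaller amounts and higher numbers for an effect only at larger amounts of compound. In this assay compound 1 gives > 21500 nM, which is a limit of the assay and not a number. Compound 2 gives > 21500 nM, again a limit. Compound 3 gives > 21500 nM, also a limit. The measured side is therefore flat: the limit of > 21500 nM in this assay, at which 3 of the 3 values shown sit.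

For the measured compounds named here, the only single-point change with a measured pair is fluoro in place of chloro on an aromatic carbon, (fluoro in place of chloro on an aromatic carbon). Its step, a step that the two limits leave unreadable from compound 2 to compound 1, cannot be read; both ends are limits. Compound 4 `CCOC(=O)c1c(-c2cccc(-c3ccccc3)c2)[nH]c2cc(OC)c(F)cc2c1=O` carries the same kind of change relative to compound 3, (fluoro in place of chloro on an aromatic carbon), but the surroundings are not the same: in compound 4 the carbon lies in a six-membered aromatic ring of carbon only that is part of a fused or bridged system of two rings, ortho to a methoxy group, meta to a fused ring and para to a fused ring, whereas in compound 1 the ring is not fused and the carbon is meta to a large group. How the core of compound 3 differs from the core of compound 2 is not broken down here.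

For compound 4 in this assay the expected step from compound 3 is a step that the limit leaves unreadable from compound 3 to compound 4, which rests on (the limit of > 21500 nM in this assay, at which 3 of the 3 values shown sit). Compound 4 is therefore expected to give 30000 nM, estimated to fall between 15000 nM and 100000 nM, most probably reported again only as a limit.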

Compound 4, half-maximal effective concentration: > 21500 nM
Compound 4 gave a limit, no number; the forecaster's own chance of this, stated with the estimate: 85%; the middle value lies beyond the limit too.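

In this assay compound 4 gives > 21500 nM, which is a limit of the assay and not a number. Compound 3 stands at a limit as well, so no step can be read between compound 3 and compound 4, and the picture is unchanged: the limit of > 21500 nM in this assay, at which 4 of the 4 values shown sit.

The compounds shown leave open what fluoro in place of chloro does in this assay, since none of the four gives a readable value there.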